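The source may report more compounds than this note shows. Statements on the series, on what has been measured and on what is new or still open speak of the compounds shown alone.

Three compounds built on a shared core were examined in an ADME assay on HepG2 2.2.15 cells (Homo sapiens) for cytotoxicity; on this read-out higher numbers stand for lower toxicity in this test and lower numbers for higher toxicity in this test. Compound 1 `CCOCC(=O)OCCc1c(-c2ccccc2Cl)c2cc(Cl)ccc2[nH]c1=O` gives 130000 nM, compound 2 `O=C(CCC1CCCCC1)OCCc1c(-c2ccccc2Cl)c2cc(Cl)ccc2[nH]c1=O` gives 160000 nM, and compound 3 `O=C(COc1ccccc1)OCCc1c(-c2ccccc2Cl)c2cc(Cl)ccc2[nH]c1=O` gives 81000 nM. The number for compound 3 is the lowest of the three, yet every step reaching it is small: a 1.6-fold lower number from compound 1 to compound 3 (0.21 log units; within the scatter) and a 2.0-fold lower number from compound 2 to compound 3 (0.30 log units; within the scatter), while the remaining comparison, a 1.2-fold higher number from compound 1 to compound 2 (0.09 log units; within the scatter), is equally modest. The next compound, compound 4 `C/C=C(\C)C(=O)OCCc1c(-c2ccccc2Cl)c2cc(Cl)ccc2[nH]c1=O`, differs from compound 3 by 1-methylprop-1-en-1-yl in place of phenoxymethyl on a carbonyl carbon. Both earlier exchanges at this carbonyl carbon left the read-out within the scatter, so a further exchange at the same place is expected to behave alike, with no step beyond the scatter in either direction. Compound 4 is therefore estimated at 120000 nM, with a range from 50000 nM to 300000 nM, in this assay. The expected step of a 1.5-fold higher number from compound 3 to compound 4 (0.17 log units; within the scatter) is thus estimated to remain inside the usual scatter.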

Compound 4, half-maximal cytotoxic concentration: 350000 nM
For compound 4 the middle estimate is 2.9-fold (0.46 log units) below the measured one; measured number outside the range, above it.
By their numbers in this assay, from the lowest: compounds 3, 1 and 2 (each within the scatter of the next); then compound 4.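

Among the compounds shown here, at this carbonyl carbon, the exchange to 1-methylprop-1-en-1-yl is the first to carry this assay beyond the scatter, with a 4.3-fold higher number from compound 3 to compound 4 (0.64 log units; beyond the scatter) and a 2.2-fold higher number from compound 2 to compound 4 (0.34 log units; beyond the scatter) and a 2.7-fold higher number from compound 1 to compound 4 (0.43 log units; beyond the scatter) as the three steps. All three point the same way, towards lower toxicity in this test, so the read-out at this place is not flat, although each step is modest. Nothing available here accounts for the shift.

The compounds shown leave open whether the higher number goes with the double bond of the entering group or with its lack of a ring. They also leave open how a plain butyl chain, an amine or a carboxylic acid on this carbonyl carbon would compare with 1-methylprop-1-en-1-yl.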